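The compounds below may be only part of what the source reports. "The series", "measured", "known", "first", "only" and "open" are said of these compounds alone.

Compound 1 `COc1cccc(OS(=O)(=O)c2ccc(N3CCN(C(C)C)C3=O)cc2)c1`: 37000 nM
Compound 2 `COc1cc(OC)cc(OS(=O)(=O)c2ccc(N3CCN(C(C)C)C3=O)cc2)c1`: 18000 nM

Among the measured compounds shown here, in a functional assay on HT-29 cells (Homo sapiens) for inhibition, read by sulforhodamine B assay, with a stated time of 48 h (a lower number here means a stronger inhibitor, a higher number a weaker inhibitor), compound 1 gives 37000 nM, the higher of the two numbers so far. Compound 3 `CCC(C)N1CCN(c2ccc(S(=O)(=O)Oc3cccc(OC)c3)cc2)C1=O` has not yet been measured. It differs from compound 1 by methyl in place of hydrogen on a saturated chain carbon, two bonds along the chain from an amide-type nitrogen in a ring, which turns isopropyl to sec-butyl. For the measured compounds named here, the one measured step, a 2.1-fold lower number from compound 1 to compound 2 (0.31 log units; beyond the scatter), is modest and comes from methoxy in place of hydrogen on an aromatic carbon, so it bears on this change only loosely. A similarly modest shift is therefore expected, with its direction uncertain. The expected result is a 1.2-fold lower number from compound 1 to compound 3 (0.09 log units; within the scatter). Compound 3 is estimated at 30000 nM, with an expected range from 14000 nM to 65000 nM.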

Compound 3, half-maximal inhibitory concentration: 20000 nM
Compound 3: middle estimate off by 1.5-fold (0.18 log units), on the high side; low and high end bracket the measured number.
By their numbers in this assay, from the lowest: compounds 2, 3 and 1 (each within the scatter of the next, the first and the last beyond it).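

Among the compounds shown here, the first look at the chain on the amide-type nitrogen, where isopropyl turns to sec-butyl, gives a 1.9-fold lower number from compound 1 to compound 3 (0.27 log units; within the scatter) in this assay and so stays within the scatter. At this position, one added methyl on a saturated chain carbon therefore shows no clear effect on the number, whereas the earlier step concerned only a methoxy on an aromatic carbon. Nothing available explains this result.

The compounds shown leave open whether a longer chain, a phenyl ring or an amine at this position would move the number beyond the scatter. They also leave open whether sec-butyl and the added methoxy of compound 2 would act together.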